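The source may report more compounds than this note shows. Statements on the series, on what has been measured and on what is new or still open speak of the compounds shown alone.

Values so far in an ADME assay on RAW264.7 cells (Mus musculus) for cytotoxicity, read by MTT assay; a higher number here means a weaker inhibitor, a lower number a stronger inhibitor

Compound 1 `CC(C)CCOc1cccc(O)c1C(=O)/C=C/c1ccc(O)cc1` gives > 30000 nM
Compound 2 `CCCCCCCCOc1cccc(O)c1C(=O)/C=C/c1ccc(O)cc1` gives > 30000 nM
Compound 3 `CCCCCCCCCCOc1cccc(O)c1C(=O)/C=C/c1ccc(O)cc1` gives > 30000 nM

Each of these entries is a limit of the assay and not a number. Compound 3 gives > 30000 nM here, and that is a limit. All the measured compounds sit together there (the limit of > 30000 nM in this assay, at which 3 of the 3 values shown sit).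

Compound 4 `O=C(/C=C/c1ccc(O)cc1)c1c(O)cccc1OCC1CCCCC1` differs from compound 3 in one place (cyclohexyl in place of nonyl on a saturated chain carbon bound to an oxygen on an aromatic ring) with cyclohexyl in place of nonyl on a saturated chain carbon bound to an oxygen on an aromatic ring. Within the data shown here, the steps that bear on this are the chain changes (a step that the two limits leave unreadable from compound 1 to compound 2) and (a step that the two limits leave unreadable from compound 1 to compound 3) and (a step that the two limits leave unreadable from compound 2 to compound 3) and none of them has a readable size. None of them brings in a ring either. With no size to carry over, no step beyond the scatter is expected in this assay and no direction is favoured, and another limit is the likeliest report. The estimated step is (a step that the limit leaves unreadable from compound 3 to compound 4) on that reading. For compound 4 the expected value is 40000 nM with an estimated range from 15000 nM to 100000 nM as a rough guide.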

Compound 4, half-maximal inhibitory concentration: > 30000 nM
Compound 4 was reported as a limit; the forecaster's own chance of this, stated with the estimate: 85%; the middle value does not contradict the limit.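

In this assay compound 4 gives > 30000 nM, which is a limit. No step from compound 1, compound 2 or compound 3 to compound 4 can be read, because all four entries share one limit: the limit of > 30000 nM in this assay, at which 4 of the 4 values shown sit.

The compounds shown leave open whether any group at this place on the shared core would give a readable value in this assay.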